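Benzylsulfanyl for methylsulfanyl on two nucleoside cores

A few compounds are considered here, and "the series" means these few. Any claim that something is new, unique, unknown or untested is made for them only; others in the source may bear on it.

Three compounds were measured in a functional assay on HFF cells (Homo sapiens) for inhibition; on this read-out higher numbers stand for weaker inhibition and lower numbers for stronger inhibition. Compound 1 `CSc1nc2cnsc2n1[C@H]1C[C@H](O)[C@@H](CO)O1` and compound 2 `OC[C@H]1O[C@@H](n2c(SCc3ccccc3)nc3cnsc32)C[C@@H]1O` share one core, while compound 3 `CSc1nc2c(C)nsc2n1[C@@H]1O[C@H](CO)[C@@H](O)[C@@H]1O` has a different core. In this assay compound 1 gives only a limit, > 100000 nM. Compound 2 likewise gives only a limit in this assay, > 100000 nM. For compound 3 this assay also reports only a limit, > 100000 nM. The change from compound 1 to compound 2 is phenyl in place of hydrogen on a saturated chain carbon bound to a sulfur, and the step it made, a step that the two limits leave unreadable from compound 1 to compound 2, cannot be sized from two limits.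

Compound 4 `Cc1nsc2c1nc(SCc1ccccc1)n2[C@@H]1O[C@H](CO)[C@@H](O)[C@@H]1O` has not been measured. It differs from compound 3 by phenyl in place of hydrogen on a saturated chain carbon bound to a sulfur, the same change as from compound 1 to compound 2. How the core of compound 3 differs from that of compound 1 is not broken down here.

Beside a step that the two limits leave unreadable from compound 1 to compound 2, the step that the limit leaves unreadable from compound 3 to compound 4 is expected to stay unreadable as well, because the limit of > 100000 nM in this assay, at which 3 of the 3 values shown sit, shows every value so far sitting at that limit. Compound 4 is therefore estimated to give 150000 nM in this assay, most likely reported again only as a limit.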

Compound 4, half-maximal inhibitory concentration: > 100000 nM
Compound 4 ended at the assay's limit; the forecaster's own chance of this, stated with the estimate: 85%; the middle value is on the limit's open side.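

In this assay compound 4 gives > 100000 nM, which is a limit and not a number. The step from compound 3 to compound 4 therefore cannot be read, and all four compounds stop at the same limit: the limit of > 100000 nM in this assay, at which 4 of the 4 values shown sit.

The compounds shown leave open whether methylsulfanyl to benzylsulfanyl changes inhibition on either core: none of them yields an actual number.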